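From methyl to nitro on the shared core

A few compounds are considered here, and "the series" means these few. Any claim that something is new, unique, unknown or untested is made for them only; others in the source may bear on it.

Compound 1 `O=C(CCCCCCC(=O)Nc1nc2ccccc2s1)NO`: 4.01 ug/mL
Compound 2 `Cc1ccc2nc(NC(=O)CCCCCCC(=O)NO)sc2c1`: 0.56 ug/mL

Both compounds were tested in a functional assay on SW-620 cells (Homo sapiens) for cytotoxicity; a lower number here means a stronger inhibitor, a higher number a weaker inhibitor. Compound 2 holds the lower of the two numbers at 0.56 ug/mL, which makes it the stronger inhibitor of the pair. Going by the values given here, the only measured step is a 7.2-fold lower number from compound 1 to compound 2 (0.85 log units; beyond the scatter), with methyl in place of hydrogen on an aromatic carbon, and it lies beyond the scatter.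

Compound 3 `O=C(CCCCCCC(=O)Nc1nc2ccc([N+](=O)[O-])cc2s1)NO` is the next to be measured. Its change from compound 2 is nitro in place of methyl on an aromatic carbon. Among the compounds with values here, no measured compound carries a nitro group, so the evidence is thin. Within the data shown here, the one available guide is the methyl gain in a 7.2-fold lower number from compound 1 to compound 2 (0.85 log units; beyond the scatter), and compound 3 gives that methyl up again. A move back toward a higher number is therefore expected, though probably a smaller one than that step, since nitro is not hydrogen and its effect here is unmeasured. The expected step is a 2.7-fold higher number from compound 2 to compound 3 (0.43 log units; beyond the scatter). For compound 3 the estimated value is 1.5 ug/mL. The expected range for compound 3 runs from 0.4 ug/mL to 5.5 ug/mL.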

Compound 3, half-maximal inhibitory concentration: 0.29 ug/mL
Compound 3: the middle estimate sits 5.2-fold (0.71 log units) above what was measured, and the stated range ends above it.
By their numbers in this assay, from the lowest: compounds 3 and 2 (each within the scatter of the next); then compound 1.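

In this assay, nitro on this aromatic carbon gives a 14-fold lower number from compound 1 to compound 3 (1.14 log units; beyond the scatter), a large step beyond the scatter, so the earlier drop from replacing hydrogen is no longer tied to methyl alone. Nitro and methyl cannot be told apart at this position, as a 1.9-fold lower number from compound 2 to compound 3 (0.29 log units; within the scatter) lies within the scatter, even though the two groups differ in their heavy atoms and hydrogen-bond acceptors. Nothing at hand explains why either group gives a lower number than hydrogen at this carbon.

Two groups at one position leave open whether an amine, a methoxy group or a chlorine atom on the same carbon would also stay close to compound 2 and compound 3, or would return toward compound 1. Going by these compounds, it also remains open whether the same replacement of hydrogen would hold up with a shorter or longer chain leading to the hydroxamic acid, or on another carbon of the same six-membered aromatic ring.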